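A few compounds are considered here, and "the series" means these few. Any claim that something is new, unique, unknown or untested is made for them only; others in the source may bear on it.

Measured compounds:
Compound 1 `COc1ccc(CN(c2cc(OC)c(OC)c(OC)c2)S(=O)(=O)c2c(C)cc(C)cc2C)cc1`: in a functional assay on PC-3 cells (Homo sapiens) for inhibition, read by MTT assay, with a stated time of 48 h (on this read-out lower numbers stand for stronger inhibition and higher numbers for weaker inhibition), compound 1 gives 14800 nM.
Compound 2 `COc1cc(N(Cc2ccc(F)cc2)S(=O)(=O)c2ccc(C)cc2)cc(OC)c1OC`: in this assay compound 2 gives 20700 nM.

Compound 2 stands at the highest of the two numbers shown, but its nearest neighbour, compound 1, lies within the scatter of it, so the two cannot be set in any order. Compound 3 `COc1cc(N(Cc2ccccc2)S(=O)(=O)c2ccc(C)cc2)cc(OC)c1OC` has not yet been measured. It differs from compound 2 in one place: hydrogen in place of fluoro on an aromatic carbon. Loss of a single fluorine at this position, with nothing else moved, is the kind of small change for which no step between measured compounds is available here. A step no larger than the scatter is expected, in either direction or none at all, and the estimated change from compound 2 to compound 3 is a 1.1-fold higher number from compound 2 to compound 3 (0.03 log units; within the scatter). Compound 3 is therefore expected to give about 22000 nM in this assay, most likely between 8000 nM and 60000 nM.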

Compound 3, half-maximal inhibitory concentration: 7810 nM
The estimate for compound 3 lay 2.8-fold (0.45 log units) above the measured number; the whole stated range lies above it.
By their numbers in this assay, from the lowest: compounds 3, 1 and 2 (each within the scatter of the next, the first and the last beyond it).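

With the fluoro of the 4-fluorobenzyl group replaced by hydrogen, this assay shows a 2.7-fold lower number from compound 2 to compound 3 (0.42 log units; beyond the scatter), so this position on the benzyl ring is not indifferent to a change of a single atom. Compounds 1 and 2 differ in more than one place and could not show this; here the unsubstituted benzyl group gives the stronger inhibition of the pair, and the fluoro brings no gain in this setting. Nothing at hand bears on why the loss of this one atom shifts the number.

On these data alone, whether the same position would respond to a chloro, an amine or a carboxylic acid remains open. So does whether the step from 4-fluorobenzyl to benzyl would hold with a different sulfonyl group, since it rests on this one pair.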